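Fluoro to nitro at one aromatic carbon

This account rests on a few compounds, and the source may have more. Where it says the series, first, only, none or still open, it means among the compounds named here.

Values so far from a functional assay on PC-3 cells (Homo sapiens) for antiproliferative activity, read by MTT assay, with a stated time of 72 h (a lower number here means a stronger inhibitor, a higher number a weaker inhibitor), are these
- compound 1 `O=C(N/N=C/c1ccccc1)Nc1ccc(Oc2ccnc3[nH]ccc23)cc1` gives 10200 nM as its value
- compound 2 `O=C(N/N=C/c1ccc(F)cc1)Nc1ccc(Oc2ccnc3[nH]ccc23)cc1` gives 7490 nM as its value

Among the compounds with values here, only two numbers exist so far. Compound 2 at 7490 nM lies within the scatter of compound 1 at 10200 nM in this assay and the two are not ranked.

Next in the series is compound 3 `O=C(N/N=C/c1ccc([N+](=O)[O-])cc1)Nc1ccc(Oc2ccnc3[nH]ccc23)cc1` with nitro in place of fluoro on an aromatic carbon, para to a large group nitro in place of fluoro on an aromatic carbon and the rest of compound 2 kept.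

Within the data shown here, one measured step bears on this place: a 1.4-fold lower number from compound 1 to compound 2 (0.13 log units; within the scatter) with fluoro in place of hydrogen. That step stays within the scatter. Among the measured compounds shown here, no measured compound carries nitro, so the step gives weak guidance and no direction. No change beyond the scatter is expected, though the range is kept wide.

The estimate amounts to a 1.1-fold lower number from compound 2 to compound 3 (0.03 log units; within the scatter) in this assay as an expected step. For compound 3 the estimated value is 7000 nM with an expected range from 3000 nM to 16000 nM in this assay as the read-out.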

Compound 3, half-maximal inhibitory concentration: 28100 nM
Estimate against measurement, compound 3: 4.0-fold (0.60 log units) below; measured number above the stated range.
By their numbers in this assay, from the lowest: compounds 2 and 1 (each within the scatter of the next); then compound 3.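

In this assay, the aromatic carbon para to a large group now proves sensitive to what it carries: the change to nitro gives a 3.8-fold higher number from compound 2 to compound 3 (0.57 log units; beyond the scatter), whereas fluoro in place of hydrogen had stayed within the scatter. The comparison with hydrogen at the same carbon points the same way, with a 2.8-fold higher number from compound 1 to compound 3 (0.44 log units; beyond the scatter), so of the two groups shown at this carbon only nitro separates from hydrogen, and it does so toward weaker inhibition. With the 4-nitrophenyl compound, the series therefore has its first step at this position that can be read as a real difference, and that step is a loss of activity. No measurement given here explains this loss.

Three compounds carrying hydrogen, fluoro and nitro at one carbon are too few to establish a trend across substituents. An amine, a methoxy group or a carboxylic acid at the same carbon would test whether the higher number is particular to nitro or extends to other groups, and whether any group at this carbon can lower the number beyond the scatter.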